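A Second Methyl on a Cyanocoumarin Core

This account rests on a few compounds, and the source may have more. Where it says the series, first, only, none or still open, it means among the compounds named here.

Of the compounds shown here, three have been measured in a functional assay on the whole organism (strain Wistar) for inhibition, with Rattus norvegicus as the target; a higher number here means that more compound is needed for the effect, a lower number that less compound is needed. Compound 1 `Cc1ccc2oc(=O)c(C#N)c(O)c2c1` gives 497 umol/kg. Compound 3 `Cc1cc2oc(=O)c(C#N)c(O)c2cc1C` gives 15.2 umol/kg. The step of a 33-fold lower number from compound 1 to compound 3 (1.51 log units; beyond the scatter) is methyl in place of hydrogen on an aromatic carbon.

Compound 2 `Cc1cccc2c(O)c(C#N)c(=O)oc12` gives 32.8 umol/kg in this assay, which stands between the other two numbers. Compound 2 and compound 1 are built from the same atoms joined differently; the difference between the two cores is not broken down here.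

Compound 4 `Cc1ccc2c(O)c(C#N)c(=O)oc2c1C` has not yet been measured in this assay. Among the measured compounds shown here, it differs from compound 2 by methyl in place of hydrogen on an aromatic carbon, which is the same change as the one from compound 1 to compound 3, and it sits at the same kind of place in both pairs. For the measured compounds named here, the only guide to its size is the single step from compound 1 to compound 3, and that step was measured on a core that differs from the core of compound 2, so a repeat of the same size is uncertain.

Compound 4 is expected to give about 4 umol/kg in this assay, within a range from 1 umol/kg to 20 umol/kg. The estimated step of an 8.2-fold lower number from compound 2 to compound 4 (0.91 log units; beyond the scatter) is expected to be clearly lower, because of the step of a 33-fold lower number from compound 1 to compound 3 (1.51 log units; beyond the scatter), but not as large as that one, since the two cores are not the same.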

Compound 4, dose for half-maximal effect: 26.2 umol/kg
Beside the measured number, compound 4's estimate is 6.6-fold (0.82 log units) below it; measured number above the stated range.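

In this assay, among the compounds shown here, methyl in place of hydrogen on an aromatic carbon gives a 1.3-fold lower number from compound 2 to compound 4 (0.10 log units; within the scatter), so on this core the added methyl leaves no step that can be told from the ordinary spread of repeated measurements. Set beside the earlier step, the same change clearly does not carry the same size from one core to the other: the same change on two cores in this assay, a 33-fold lower number (1.51 log units; beyond the scatter) from compound 1 to compound 3 and a 1.3-fold lower number (0.10 log units; within the scatter) from compound 2 to compound 4, 26-fold (1.42 log units) apart, beyond the scatter of two such steps This shows that the large step seen on the core of compound 1 cannot simply be transferred to the core of compound 2, but with only two pairs it does not show which difference between the cores is responsible, nor what the same change would do on a third core.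

All the substituents on the carbon ring in the compounds shown are methyl groups, so it remains open whether an ethyl group, a longer chain or a methoxy group at this place on the core of compound 2 would give a step beyond the scatter. Going by these compounds, it also remains open whether a group of a different kind, such as an amine or a carboxylic acid, would behave differently on the two cores.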